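The source may hold more compounds than are shown below. What is called first, only, known or untested is meant among the compounds shown, and "the series" means these compounds.

Three compounds sharing one core differ only in the group on an amide-type nitrogen. Compound 1 `Nc1n[nH]c2cccc(-c3cccc(NC(=O)Nc4ccccc4F)c3)c12` gives 2360 nM in a functional assay on SMMC-7721 cells (Homo sapiens) for inhibition, read by MTT assay, with a stated time of 48 h; on this read-out lower numbers stand for stronger inhibition and higher numbers for weaker inhibition. Compound 2 `Nc1n[nH]c2cccc(-c3cccc(NC(=O)Nc4cccc(F)c4)c3)c12` gives 1240 nM, and compound 3 `Nc1n[nH]c2cccc(-c3cccc(NC(=O)Nc4cccc(C(F)(F)F)c4)c3)c12` gives 1410 nM. Compound 3 stands second highest of the three numbers: the steps of a 1.7-fold lower number from compound 1 to compound 3 (0.22 log units; within the scatter) and a 1.1-fold higher number from compound 2 to compound 3 (0.06 log units; within the scatter) both lie within the scatter, as does a 1.9-fold lower number from compound 1 to compound 2 (0.28 log units; within the scatter). Compound 4 `Nc1n[nH]c2cccc(-c3cccc(NC(=O)Nc4nccs4)c3)c12` differs from compound 3 by 1,3-thiazol-2-yl in place of 3-(trifluoromethyl)phenyl on an amide-type nitrogen. The measured steps bear on this change only in that every swap of the group on this nitrogen so far has moved nothing beyond the scatter, and none of them brought in a five-membered aromatic ring with hetero atoms. A step of about a 1.4-fold higher number from compound 3 to compound 4 (0.15 log units; within the scatter) is therefore expected, none beyond the scatter. Compound 4 is expected to give 2000 nM, between 700 nM and 6000 nM.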

Compound 4, half-maximal inhibitory concentration: 550 nM
For compound 4 the middle estimate is 3.6-fold (0.56 log units) above the measured one; measured number outside the range, below it.
By their numbers in this assay, from the lowest: compound 4; then compounds 2, 3 and 1 (each within the scatter of the next).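

At this amide-type nitrogen, the choice of group can move the number in this assay beyond the scatter: 1,3-thiazol-2-yl gives a 2.6-fold lower number from compound 3 to compound 4 (0.41 log units; beyond the scatter) and a 2.3-fold lower number from compound 2 to compound 4 (0.35 log units; beyond the scatter) and a 4.3-fold lower number from compound 1 to compound 4 (0.63 log units; beyond the scatter) with all three steps modest. Compound 4 is also the only one shown with a five-membered aromatic ring with hetero atoms in place of a six-membered carbon ring. Nothing available explains this gain. The compounds shown leave open whether it follows the ring's sulfur, its nitrogen or its smaller size. A 1,3-oxazol-2-yl or a pyridin-2-yl group on this nitrogen would help separate these.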